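Shortening the Amine Tail of a Vitamin D Receptor Agonist

This account rests on a few compounds, and the source may have more. Where it says the series, first, only, none or still open, it means among the compounds named here.

Measured so far:
compound 1 `CCN(CC)CCNC(=O)c1ccc(C(CC)(CC)c2ccc(OCC(=O)C(C)(C)C)c(C)c2)n1CC` – 91 nM
compound 2 `CCn1c(C(=O)NCCCN(C)C)ccc1C(CC)(CC)c1ccc(OCC(=O)C(C)(C)C)c(C)c1` – 96 nM

In an assay on HL-60 cells for agonist activity at vitamin D3 receptor (Homo sapiens), read by microscopy, with a stated time of 96 h (on this read-out lower numbers stand for an effect already at smaller amounts and higher numbers for an effect only at larger amounts of compound), compound 1 gives 91 nM, and compound 2 gives 96 nM. Compound 2 shows the higher of the two numbers, yet a 1.1-fold higher number from compound 1 to compound 2 (0.02 log units; within the scatter), so the two compounds cannot be told apart on this read-out.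

Compound 3 `CCn1c(C(=O)NCCN)ccc1C(CC)(CC)c1ccc(OCC(=O)C(C)(C)C)c(C)c1` has not been measured. It differs from compound 2 by amino in place of (dimethylamino)methyl on a saturated chain carbon, two bonds along the chain from an amide-type nitrogen. Among the measured compounds shown here, the only measured step bearing on this tail, a 1.1-fold higher number from compound 1 to compound 2 (0.02 log units; within the scatter), swapped one tertiary amine for another and stayed within the scatter. For the measured compounds named here, the change to compound 3 goes further, removing both alkyl groups and shortening the chain, so it is a less direct guide; no measured pair shows a primary amine here.

Compound 3 is therefore expected to stay close to compound 2, with a 1.4-fold higher number from compound 2 to compound 3 (0.13 log units; within the scatter) as the estimated step, giving an expected value of 130 nM with a likely range from 50 nM to 350 nM.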

Compound 3, half-maximal effective concentration: 120 nM
Compound 3: the middle estimate sits 1.1-fold (0.03 log units) above what was measured, and the stated range covers the measured number.
By their numbers in this assay, from the lowest: compounds 1, 2 and 3 (each within the scatter of the next).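

In this assay, the step to a primary amine is a 1.3-fold higher number from compound 2 to compound 3 (0.10 log units; within the scatter), and the step from the diethylamino tail is a 1.3-fold higher number from compound 1 to compound 3 (0.12 log units; within the scatter). The earlier pair compared only two tertiary amines, whereas these steps show that the number also stays within the scatter when the alkyl groups on the nitrogen are gone and 3-(dimethylamino)propyl gives way to 2-aminoethyl. No available evidence explains this result.

All three compounds carry a basic-looking name only in the sense of ending in an amine, so the compounds shown leave open whether the tail needs an amine at all. A carboxylic acid, a hydroxyl group or a plain ethyl chain at this place, or a much longer chain, would test whether any change here can move the number beyond the scatter.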